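Predicting the Effect of One Aromatic Group Swap

The source may report more compounds than this note shows. Statements on the series, on what has been measured and on what is new or still open speak of the compounds shown alone.

- compound 1 `COc1ccc(/C=C/C(=O)Nc2cc3c(Nc4ccc(F)c(Cl)c4)ncnc3cc2O[C@H]2CCOC2)c(OC)c1`: 26500 nM
- compound 2 `COc1ccc(/C=C/C(=O)Nc2cc3c(Nc4ccc(F)c(Cl)c4)ncnc3cc2O[C@H]2CCOC2)c(OC)c1OC`: 4830 nM
- compound 3 `COc1cc(/C=C/C(=O)Nc2cc3c(Nc4ccc(F)c(Cl)c4)ncnc3cc2O[C@H]2CCOC2)cc(OC)c1O`: not yet measured

Among the compounds with values here, in a functional assay on HeLa cells (Homo sapiens) for cytotoxicity, read by MTT assay, with a stated time of 72 h (on this read-out higher numbers stand for weaker inhibition and lower numbers for stronger inhibition), compound 2 gives 4830 nM, the lower of the two numbers so far, while compound 1 gives 26500 nM. The next structure makes a larger change to the same group: 4-hydroxy-3,5-dimethoxyphenyl in place of 2,3,4-trimethoxyphenyl on a double-bonded chain carbon bound to a double-bonded chain carbon. The shared core and the rest of the molecule stay the same.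

Within the data shown here, only one measured step bears on this change. It is a 5.5-fold lower number from compound 1 to compound 2 (0.74 log units; beyond the scatter), and the change there is methoxy in place of hydrogen on an aromatic carbon. That step shows that an edit to this aromatic group can move the number in this assay by a modest amount. Among the measured compounds shown here, it is only a loose guide, however, since no measured compound carries the 4-hydroxy-3,5-dimethoxyphenyl group. The data therefore point to no clear direction, and a step no larger than that modest one, either way, is the reasonable expectation.

The expected change is a 1.1-fold higher number from compound 2 to compound 3 (0.06 log units; within the scatter), an estimate with wide uncertainty. Compound 3 is expected at about 5500 nM, within an estimated range of 1500 nM to 20000 nM.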

Compound 3, half-maximal inhibitory concentration: 27400 nM
Beside the measured number, compound 3's estimate is 5.0-fold (0.70 log units) below it; measured number above the stated range.
By their numbers in this assay, from the lowest: compound 2; then compounds 1 and 3 (each within the scatter of the next).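

In this assay, within the data shown here, the earlier pair showed only that adding a methoxy group to this aromatic group can bring the number down, with a 5.5-fold lower number from compound 1 to compound 2 (0.74 log units; beyond the scatter) as the step. Replacing 2,3,4-trimethoxyphenyl with 4-hydroxy-3,5-dimethoxyphenyl on the double-bonded chain carbon gives a 5.7-fold higher number from compound 2 to compound 3 (0.75 log units; beyond the scatter) and so shows that this position can also move the number up, even though both groups hold 3 oxygen atoms. The comparison with 2,4-dimethoxyphenyl gives a 1.0-fold higher number from compound 1 to compound 3 (0.01 log units; within the scatter) and leaves compound 2 alone with the lowest number of the three, so the oxygen count of the group does not settle the result in these compounds.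

On these data alone, whether the step follows the hydroxy group or the different arrangement of the methoxy groups stays open, as does the effect of an amine or a carboxylic acid in place of that hydroxy group. Nothing measured here explains why these numbers differ.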